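The source may report more compounds than this note shows. Statements on the series, on what has been measured and on what is new or still open speak of the compounds shown alone.

Working notes on a small set sharing one core, all run in an assay on isolated protein for displacement of a labelled ligand from metabotropic glutamate receptor 5 (Homo sapiens), with a stated time of 60 min, tested at 1 uM; on this read-out lower numbers stand for less inhibition and higher numbers for more inhibition at the one concentration tested (going by the name of the read-out). Compound 1 `O=S(=O)(c1ccccc1)c1cnc2ccccc2c1N1CCCCCC1` gives 79.9%. Compound 2 `COc1ccc2ncc(S(=O)(=O)c3cc(F)cc(F)c3)c(N3CCC(C)CC3)c2c1` gives 30% in this assay, and compound 3 `Cc1ccc(S(=O)(=O)c2cnc3cc(F)ccc3c2N2CCC(C)CC2)cc1` gives 88%. Compound 1 thus stands second highest of the three numbers; the gap to compound 3 lies within the scatter, whereas compound 2 sits far below, beyond the scatter. Compound 4 `O=S(=O)(c1ccccc1)c1cnc2ccccc2c1N1CCCCC1` has not yet been measured in this assay. It differs from compound 1 by piperidin-1-yl in place of azepan-1-yl on an aromatic carbon. Among the compounds with values here, no measured pair isolates this change. The step of a number 7.9 percentage points lower from compound 1 to compound 4 (within the scatter) is expected to be small, at most slightly downward, and probably within the scatter. Compound 4 is accordingly estimated at 72%, with a likely range from 50% to 90%.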

Compound 4, a percentage reported as inhibition, at one concentration (the size of the read-out at that concentration, not a potency): 71.4%
Compound 4: middle estimate off by 0.6 percentage points, on the high side; the measured number falls inside the stated range.
By their numbers in this assay, from the lowest: compound 2; then compounds 4, 1 and 3 (each within the scatter of the next, the first and the last beyond it).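

In this assay, within the data shown here, this is the first pair that isolates one change on this aromatic carbon, and piperidin-1-yl in place of azepan-1-yl gives a number 8.5 percentage points lower from compound 1 to compound 4 (within the scatter). With the rest of the structure held constant, the read-out does not separate the six-membered ring from the seven-membered ring at this place. No measurement on hand explains this result. As far as these compounds go, whether morpholin-4-yl or open-chain dimethylamino keeps the read-out at this place remains open. So does whether the same ring change behaves alike with other groups on the sulfonyl.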